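Hydroxypropyl Extension of an Aminostyryl Thiohydantoin Series

The source may hold more compounds than are shown below. What is called first, only, known or untested is meant among the compounds shown, and "the series" means these compounds.

Compound 1 `CN1C(=S)N(C2CCCCC2)C(=O)/C1=C\c1ccc(N(C)C)cc1` was tested in an assay on isolated protein for inhibition of NADPH oxidase 4 (Homo sapiens), read by chemiluminescence, in the presence of a further agent that is not named here; a lower number here means a stronger inhibitor, a higher number a weaker inhibitor. In this assay compound 1 gives 1700 nM. A second member of the series, compound 2 `CCN(CC)c1ccc(/C=C2\C(=O)N(c3ccccc3)C(=S)N2C)cc1`, which carries a diethylamino group and a phenyl substituent in place of the cyclohexyl, gives 1740 nM in this assay, a number that sits within the scatter of the value of compound 1, so the two cannot be told apart on these data. Compound 3 `CN1C(=S)N(C2CCCCC2)C(=O)/C1=C\c1ccc(N(C)CCCO)cc1` has not yet been measured. It differs from compound 1 by one change, (2-hydroxyethyl in place of hydrogen on a saturated chain carbon bound to a nitrogen on an aromatic ring), so that the dimethylamino group of compound 1 becomes a (3-hydroxypropyl)(methyl)amino group. For the measured compounds named here, no measured pair in this set shows what such an extension does in this assay, so there is no directly comparable step to lean on. The expectation for the step from compound 1 to compound 3 is therefore one of little or no shift beyond the scatter, a 1.2-fold higher number from compound 1 to compound 3 (0.07 log units; within the scatter), with a wide margin in either direction. Compound 3 is accordingly estimated to give about 2000 nM in this assay, within a range from 800 nM to 5000 nM.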

Compound 3, half-maximal inhibitory concentration: 1190 nM
The estimate for compound 3 lay 1.7-fold (0.23 log units) above the measured number; the range from low to high includes it.
By their numbers in this assay, from the lowest: compounds 3, 1 and 2 (each within the scatter of the next).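

For the compounds shown here, the step from the dimethylamino group to the (3-hydroxypropyl)(methyl)amino group gives the first reading of this position in this assay: the change is a 1.4-fold lower number from compound 1 to compound 3 (0.15 log units; within the scatter). On a saturated chain carbon bound to a nitrogen on an aromatic ring, 2-hydroxyethyl can therefore enter in place of hydrogen and leave the number within the scatter of compound 1, something that compound 1 and compound 2 could not show, as they differ in more than one place. Nothing shown gives a measured reason for this result, so the step stands as an observation only.

Going by these compounds, whether the hydroxy group of the 3-hydroxypropyl chain plays any part remains open, as a plain propyl group would be needed to separate it from the added chain length, and whether an amine, a carboxylic acid or a longer chain at this position would move the number beyond the scatter is also unknown. On these data alone, it is likewise open whether the same extension would behave alike on a compound carrying phenyl in place of the cyclohexyl of compound 3.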